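This account rests on a few compounds, and the source may have more. Where it says the series, first, only, none or still open, it means among the compounds named here.

Measured compounds:
compound 1, `NCCCSC[C@H]1O[C@@H](n2cnc3c(N)ncnc32)[C@H](O)[C@@H]1O`, no result reported in an assay for inhibition of tRNA (cytosine(38)-C(5))-methyltransferase (Homo sapiens), with a stated time of 5 min, tested at 100 uM; on this read-out higher numbers stand for more inhibition at the one concentration tested (going by the name of the read-out) and lower numbers for less inhibition
compound 2, `Nc1ncnc2c1ncn2[C@@H]1O[C@H](CNC(=O)CC[C@H](N)C(=O)O)[C@@H](O)[C@H]1O`, no result reported in this assay
compound 3, `Nc1ncnc2c1ncn2[C@@H]1O[C@H](CN(CC[C@H](N)C(=O)O)CC2CCCC2)[C@@H](O)[C@H]1O`, 24.5%

Compound 3 is the only one of the three that carries a number in this assay; compounds 1 and 2 share the same core but come without a result, so nothing can be said about how they compare. Compound 3 therefore stands alone, and its value is the only anchor available.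

Compound 4, `C#CC(C)(C)N(CC[C@H](N)C(=O)O)C[C@H]1O[C@@H](n2cnc3c(N)ncnc32)[C@H](O)[C@@H]1O`, differs from compound 3 in one place: 1,1-dimethylprop-2-yn-1-yl in place of cyclopentylmethyl on an amine nitrogen. The amine nitrogen and everything else on the core stay the same.

Among the measured compounds shown here, no step between two measured compounds is known, so there is no pattern to lean on. For the measured compounds named here, with only the single value of compound 3 and a change that swaps one hydrocarbon group for another of similar size, the step is expected to be small, in no clear direction, and probably no larger than the usual scatter of this kind of measurement. Compound 4 is therefore estimated at 20%, within a range of 5% to 40%, which amounts to an expected step of a number 4.5 percentage points lower from compound 3 to compound 4 (within the scatter).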

Compound 4, a percentage reported as inhibition, at one concentration (the size of the read-out at that concentration, not a potency): 17.3%
For compound 4 the middle estimate is 2.7 percentage points above the measured one; the measured number falls inside the stated range.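

On the amine nitrogen, 1,1-dimethylprop-2-yn-1-yl in place of cyclopentylmethyl gives, in this assay, a number 7.2 percentage points lower from compound 3 to compound 4 (within the scatter). This first readable step shows that the two groups cannot be told apart on this read-out, even though one holds a five-membered non-aromatic ring of carbon only and the other has no ring but a triple bond. Nothing shown here offers an explanation for this result.

Steps involving compound 1 and compound 2 cannot be read, so the shared core offers only this one comparison. On these data alone, it remains open whether a group on this nitrogen carrying an amine or a carboxylic acid, or a longer carbon chain, would shift the inhibition by more than the usual scatter.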